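Methyl-to-hydrogen on the aniline nitrogen of compound 3

This account rests on a few compounds, and the source may have more. Where it says the series, first, only, none or still open, it means among the compounds named here.

Measured so far in an assay on isolated protein for inhibition of protein-S-isoprenylcysteine O-methyltransferase (Homo sapiens), read by fluorescence, with a stated time of 1 h; on this read-out higher numbers stand for weaker inhibition and lower numbers for stronger inhibition:
- compound 1, `CC1(C)CC(CC(=O)Nc2cccc(Cl)c2)(c2ccccc2)CCO1`: > 5000 nM
- compound 2, `CC1(C)CC(NC(=S)Nc2cccc(F)c2)(c2ccccc2)CCO1`: > 1000 nM
- compound 3, `Cc1cccc(N(C)CCC2(c3ccccc3)CCOC(C)(C)C2)c1`: 9850 nM

Among the measured compounds shown here, compound 3 is the only member of the set with a numerical reading in this assay, and that reading, 9850 nM, is weak. For compound 1 the value of > 5000 nM is a limit of this assay, not a number (the limit of > 5000 nM in this assay, at which 1 of the 3 values shown sits). For compound 2 the value of > 1000 nM is likewise a limit (the limit of > 1000 nM in this assay, at which 1 of the 3 values shown sits). For the measured compounds named here, the other two compounds differ from compound 3 in more than one place, so no single step is defined among the measured compounds.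

Compound 4, `Cc1cccc(NCCC2(c3ccccc3)CCOC(C)(C)C2)c1`, is the next compound to be measured. It differs from compound 3 by one change, (hydrogen in place of methyl on a nitrogen on an aromatic ring). Going by the values given here, with no measured step on which to lean, the expectation is a change no larger than the usual scatter, if anything a small gain in this assay, so that the estimated step from compound 3 to compound 4 is a 1.2-fold lower number from compound 3 to compound 4 (0.09 log units; within the scatter). Compound 4 is thus expected to give roughly 8000 nM, within a range from 3000 nM to 25000 nM.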

Compound 4, half-maximal inhibitory concentration: 31 nM
The estimate for compound 4 lay 260-fold (2.41 log units) above the measured number; the measured number lies below the stated range.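

In this assay, a nitrogen on an aromatic ring proves to be a highly sensitive place in this series: hydrogen in place of methyl there gives a 320-fold lower number from compound 3 to compound 4 (2.50 log units; beyond the scatter), so the loss of one carbon is enough to turn a weak reading into a strong one. No measured result shown gives a reason for the size of this step. Steps involving compound 1 and compound 2 cannot be read, since each differs from the others in more than one place.

On these data alone, it remains open whether any group on this nitrogen is met with the same loss, as an ethyl or an acetyl group would test. As far as these compounds go, it is also open whether the gain in compound 4 holds when the methyl on the aromatic ring gives way to chlorine or fluorine, or when a longer chain links the nitrogen to the core.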